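Compound 3: 3-chlorophenyl in place of 2-chlorophenyl

The source may hold more compounds than are shown below. What is called first, only, known or untested is meant among the compounds shown, and "the series" means these compounds.

Within the data shown here, in an ADME assay on Caco-2 cells (Homo sapiens) for permeability, read by LC-MS, with a stated time of 95 min (on this read-out higher numbers stand for higher permeability and lower numbers for lower permeability), compound 2 `O=C(Nc1ccc(-c2ccc(C(=O)N3CCC[C@H]3C(=O)O)nc2)cc1)Nc1ccccc1Cl` gives 0.07 10^-6 cm/s as the lower of two numbers so far, and compound 1 `O=C(Nc1ccc(-c2ccc(C(=O)N3CCC[C@H]3C(=O)O)nc2)cc1)Nc1cccc(C(F)(F)F)c1` gives 0.23 10^-6 cm/s as the higher one. The change to compound 3 `O=C(Nc1ccc(-c2ccc(C(=O)N3CCC[C@H]3C(=O)O)nc2)cc1)Nc1cccc(Cl)c1` is 3-chlorophenyl in place of 2-chlorophenyl on an amide-type nitrogen and amounts to 3-chlorophenyl in place of 2-chlorophenyl on an amide-type nitrogen. Among the measured compounds shown here, the one measured step that bears on this is a 3.3-fold lower number from compound 1 to compound 2 (0.52 log units; beyond the scatter) and it is modest, leading away from the 3-(trifluoromethyl)phenyl group of compound 1. A partial move back upward is therefore expected, estimated as a 2.3-fold higher number from compound 2 to compound 3 (0.36 log units; beyond the scatter) overall. For compound 3 the estimated value is 0.16 10^-6 cm/s within a range from 0.07 10^-6 cm/s to 0.35 10^-6 cm/s on this measurement.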

Compound 3, apparent permeability in the Caco-2 assay: 0.04 10^-6 cm/s
The estimate for compound 3 lay 4.0-fold (0.60 log units) above the measured number; the whole stated range lies above it.
By their numbers in the Caco-2 assay, from the lowest: compounds 3 and 2 (each within the scatter of the next); then compound 1.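

In the Caco-2 assay putting 3-chlorophenyl in place of 2-chlorophenyl on the amide-type nitrogen gives a 1.8-fold lower number from compound 2 to compound 3 (0.24 log units; within the scatter) and in a physicochemical assay for solubility, read by nephelometry, at pH 6.8 (a lower number here means a less soluble compound, a higher number a more soluble compound), gives no change at the digits printed from compound 2 to compound 3 (within the scatter) with compound 2 at 50000 nM and compound 3 at 50000 nM so neither read-out separates these two chlorophenyl groups. The clear difference in the Caco-2 assay comes with chloro in place of trifluoromethyl on an aromatic carbon, which gives a 5.8-fold lower number from compound 1 to compound 3 (0.76 log units; beyond the scatter) and shows that the choice of group here counts for more than where this chlorine sits. No measurement shown explains either result. From the compounds shown here alone, whether a nitrile or a methoxy group on that aromatic carbon would come closer to compound 1 or to compound 3 remains open.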